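A Flat Series Meets a Trifluoromethyl Swap

The source may hold more compounds than are shown below. What is called first, only, known or untested is meant among the compounds shown, and "the series" means these compounds.

Among the measured compounds shown here, in an ADME assay on L02 cells (Homo sapiens) for cytotoxicity, read by MTT assay, with a stated time of 24 h (on this read-out lower numbers stand for stronger inhibition and higher numbers for weaker inhibition), three compounds have numbers so far, and they sit close together. Compound 1 (`O=C1/C(=C/c2cccnc2)CNC/C1=C\c1ccccc1F`) gives 15900 nM and compound 2 (`O=C1/C(=C/c2ccncc2)CNC/C1=C\c1ccccc1F`) gives 14700 nM while compound 3 (`O=C1/C(=C/c2ccncc2)CN(S(=O)(=O)c2ccc(F)cc2)C/C1=C\c1ccccc1F`) gives 15600 nM and so compound 2 stands level with both others, within the usual scatter of repeat measurements.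

Compound 4 (`O=C1/C(=C/c2ccncc2)CNC/C1=C\c1ccccc1C(F)(F)F`) differs from compound 2 in one place, and the change trifluoromethyl in place of fluoro on an aromatic carbon puts trifluoromethyl in place of fluoro on an aromatic carbon.

Two measured steps offer indirect guidance. Replacing pyridin-3-yl with pyridin-4-yl gave a 1.1-fold lower number from compound 1 to compound 2 (0.03 log units; within the scatter) and adding (4-fluorophenyl)sulfonyl on the amine nitrogen gave a 1.1-fold higher number from compound 2 to compound 3 (0.03 log units; within the scatter) and both lie within the scatter. For the measured compounds named here, neither step touches the fluoro group, so no measurement yet shows what a swap at this aromatic carbon does. Going by the values given here, the two flat steps are the only guide, which leaves the margins wide.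

No step beyond the scatter is therefore expected in this assay for this change. The expected step of a 1.1-fold lower number from compound 2 to compound 4 (0.02 log units; within the scatter) is small and has no firm direction. Compound 4 is expected at 14000 nM within an estimated range of 7000 nM to 28000 nM on this read-out.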

Compound 4, half-maximal inhibitory concentration: 13400 nM
Compound 4: the middle estimate sits 1.0-fold (0.02 log units) above what was measured; low and high end bracket the measured number.
By their numbers in this assay, from the lowest: compounds 4, 2, 3 and 1 (each within the scatter of the next).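

Among the compounds shown here, the swap to trifluoromethyl is the first measured change at this aromatic carbon, and in this assay it gives a 1.1-fold lower number from compound 2 to compound 4 (0.04 log units; within the scatter). This place, on an aromatic carbon of a six-membered aromatic ring of carbon only and ortho to a large group, therefore accepts 4 heavy atoms in place of 1 with no step beyond the scatter, so all three single-place steps in the series now read as flat, although this one concerns a different place from the earlier two. No measurement is available that could explain this flat result.

Only fluoro and trifluoromethyl have been read at this aromatic carbon, so the compounds shown leave open whether a group without fluorine, such as an amine, a methoxy group or a carboxylic acid, would also stay within the scatter. They also leave open whether trifluoromethyl at this carbon would read the same alongside the (4-fluorophenyl)sulfonyl group of compound 3 or the pyridin-3-yl group of compound 1.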